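Relocating a Hydroxyl on the Phenoxy Arm

This account rests on a few compounds, and the source may have more. Where it says the series, first, only, none or still open, it means among the compounds named here.

Compound 2 `Cc1ccc(S(=O)(=O)Nc2ccc3c(c2)C(=O)N(CCOc2cccc(O)c2)C3=O)cc1` carries a (3-hydroxyphenoxy)methyl group on the saturated chain carbon bound to the amide-type nitrogen of the shared core. In an assay on isolated protein for inhibition of lactase/phlorizin hydrolase (Rattus norvegicus), read by colorimetric assay (a lower number here means a stronger inhibitor, a higher number a weaker inhibitor), compound 2 gives 111000 nM. Among the measured compounds shown here, that is the lowest of the two numbers recorded, but its only neighbour, compound 1 `Cc1ccc(S(=O)(=O)Nc2ccc3c(c2)C(=O)N(Cc2ccc(Cl)cc2)C3=O)cc1`, which has 4-chlorophenyl at the same place, gives 155000 nM, and the step of a 1.4-fold lower number from compound 1 to compound 2 (0.15 log units; within the scatter) does not exceed the scatter, so the two cannot be ranked against each other.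

Compound 3 `Cc1ccc(S(=O)(=O)Nc2ccc3c(c2)C(=O)N(CCOc2ccc(O)cc2)C3=O)cc1` is built from the same atoms joined differently: 4-hydroxyphenyl in place of 3-hydroxyphenyl on an oxygen on a saturated carbon. For the measured compounds named here, no measured step bears directly on this change; the only step recorded swapped a whole group at that arm and still stayed within the scatter. With no evidence that this series responds to where the hydroxyl sits, the expectation is no step beyond the scatter, a 1.0-fold higher number from compound 2 to compound 3 (0.02 log units; within the scatter), in this assay. Compound 3 is therefore estimated at 115000 nM, within a range from 50000 nM to 260000 nM.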

Compound 3, half-maximal inhibitory concentration: 100000 nM
For compound 3 the middle estimate is 1.2-fold (0.06 log units) above the measured one, and the stated range covers the measured number.
By their numbers in this assay, from the lowest: compounds 3, 2 and 1 (each within the scatter of the next).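

Moving the hydroxyl, with 4-hydroxyphenyl in place of 3-hydroxyphenyl on the oxygen, gives in this assay a 1.1-fold lower number from compound 2 to compound 3 (0.05 log units; within the scatter) and so offers the first direct test of where this hydroxyl sits: the two placements cannot be told apart. The wider swap from the 4-chlorophenyl group to the (4-hydroxyphenoxy)methyl group gives a 1.6-fold lower number from compound 1 to compound 3 (0.19 log units; within the scatter) and also stays inside the scatter, so none of the three compounds can be ranked against the others, even though compounds 1 and 3 differ in a whole group at this position. Nothing available accounts for this flat result.

The compounds shown do not reveal whether the hydroxyl matters at all, a question that a plain phenoxy group or a methoxy group in its place could address. On these data alone, it also remains open whether a quite different group on this arm, such as an amine, a carboxylic acid or a longer chain, would shift the number beyond the scatter.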